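Carbonyl substituent change: dimethylamino to cyanoamino

The source may report more compounds than this note shows. Statements on the series, on what has been measured and on what is new or still open speak of the compounds shown alone.

Among the compounds with values here, in a physicochemical assay for solubility, using the shake flask method, in simulated intestinal fluid, measured as kinetic solubility, with a stated time of 2 h, at 25 degrees C, at pH 6.5 (a higher number here means a more soluble compound, a lower number a less soluble compound), compound 3 `Cc1nc(C(=O)N(C)C)c(N)c2c1C(=O)N(Cc1ccccc1)C2=O` gives 172000 nM, the highest of the three numbers so far. Compound 2 `CNC(=O)c1nc(C)c2c(c1N)C(=O)N(Cc1ccccc1)C2=O` gives 41000 nM and compound 1 `COC(=O)c1nc(C)c2c(c1N)C(=O)N(Cc1ccccc1)C2=O` gives 7400 nM. Compound 4 `Cc1nc(C(=O)NC#N)c(N)c2c1C(=O)N(Cc1ccccc1)C2=O` has cyanoamino in place of dimethylamino on a carbonyl carbon. The measured steps at this carbonyl carbon are a 23-fold higher number from compound 1 to compound 3 (1.37 log units; beyond the scatter), which is large, and a 5.5-fold higher number from compound 1 to compound 2 (0.74 log units; beyond the scatter) and a 4.2-fold higher number from compound 2 to compound 3 (0.62 log units; beyond the scatter), both modest. None of them includes a cyanoamino group, so they bear on the change only loosely. Compound 4 keeps a hydrogen on the amide-type nitrogen, as compound 2 does, which points to a lower number, if any change appears. The expected move is a 1.6-fold lower number from compound 3 to compound 4 (0.19 log units; within the scatter), not beyond the scatter. For compound 4 the estimated value is 110000 nM, with an expected range of 30000 nM to 300000 nM.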

Compound 4, solubility: 185000 nM
Compound 4: the middle estimate sits 1.7-fold (0.23 log units) below what was measured; the measured number falls inside the stated range.
By their numbers in this assay, from the lowest: compound 1; then compound 2; then compounds 3 and 4 (each within the scatter of the next).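

In this assay cyanoamino and dimethylamino on this carbonyl carbon cannot be told apart (a 1.1-fold higher number from compound 3 to compound 4 (0.03 log units; within the scatter)). A hydrogen on the amide-type nitrogen does not by itself hold a compound at the level of compound 2, since cyano in place of methyl gives a 4.5-fold higher number from compound 2 to compound 4 (0.65 log units; beyond the scatter), and the gain over methoxy also stands (a 25-fold higher number from compound 1 to compound 4 (1.40 log units; beyond the scatter)). Nothing available explains this result. Still open, from the compounds shown here alone, is how this assay would read with a longer chain or a hydroxyethyl group on the amide-type nitrogen.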